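A few compounds are considered here, and "the series" means these few. Any claim that something is new, unique, unknown or untested is made for them only; others in the source may bear on it.

Measured in an ADME assay on Vero cells (Chlorocebus sabaeus) for cytotoxicity, read by MTT assay, with a stated time of 72 h; on this read-out higher numbers stand for lower toxicity in this test and lower numbers for higher toxicity in this test: compound 1 `N/C(=N/NC(CC(=O)c1ccc(-n2ccnc2)cc1)c1ccccc1[N+](=O)[O-])c1ccccn1` gives 48000 nM; compound 2 `N/C(=N/NC(CC(=O)c1ccc(-n2ccnc2)cc1)c1cccc(Br)c1)c1ccccn1` gives 51300 nM; compound 3 `N/C(=N/NC(CC(=O)c1ccc(-n2ccnc2)cc1)c1ccc(Cl)cc1)c1ccccn1` gives 78800 nM.

Compound 3 has the highest number of the three, yet its gaps to compound 2 and compound 1 both lie within the scatter: a 1.5-fold higher number from compound 2 to compound 3 (0.19 log units; within the scatter) and a 1.6-fold higher number from compound 1 to compound 3 (0.22 log units; within the scatter). Compound 4 `N/C(=N/NC(CC(=O)c1ccc(-n2ccnc2)cc1)c1ccc(Br)cc1)c1ccccn1` differs from compound 3 by bromo in place of chloro on an aromatic carbon. Among the compounds with values here, no measured step exchanges one halogen for another on the same ring carbon; the steps that bear on it, a 1.1-fold higher number from compound 1 to compound 2 (0.03 log units; within the scatter) and a 1.5-fold higher number from compound 2 to compound 3 (0.19 log units; within the scatter), each replace the whole aryl group and stay within the scatter. A step of no more than the scatter is therefore expected in this assay, a 1.1-fold lower number from compound 3 to compound 4 (0.05 log units; within the scatter). Compound 4 is estimated at 70000 nM, range 35000 nM to 140000 nM.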

Compound 4, half-maximal cytotoxic concentration: 298000 nM
For compound 4 the middle estimate is 4.3-fold (0.63 log units) below the measured one; the measured number lies above the stated range.
By their numbers in this assay, from the lowest: compounds 1, 2 and 3 (each within the scatter of the next); then compound 4.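

In this assay, bromo in place of chloro on an aromatic carbon para to a large group gives a 3.8-fold higher number from compound 3 to compound 4 (0.58 log units; beyond the scatter), the first single-atom exchange shown here and a step beyond the scatter. The 4-bromophenyl group also stands apart from the other aryl groups, with a 5.8-fold higher number from compound 2 to compound 4 (0.76 log units; beyond the scatter) and a 6.2-fold higher number from compound 1 to compound 4 (0.79 log units; beyond the scatter), whereas the aryl exchanges among compounds 1, 2 and 3 all stayed within the scatter. No available evidence accounts for this step.

Open, on these data alone, is whether fluoro, iodo or methyl on the same aromatic carbon would fall with compound 3 or with compound 4.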